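A Trifluoromethyl Group on Compound 1

The source may report more compounds than this note shows. Statements on the series, on what has been measured and on what is new or still open speak of the compounds shown alone.

Among the measured compounds shown here, in a functional assay on MCF7 cells (Homo sapiens) for inhibition, read by CCK-8 assay, with a stated time of 72 h (on this read-out higher numbers stand for weaker inhibition and lower numbers for stronger inhibition), compound 1 (`Fc1ccc(CNc2nc(Nc3cc(C4CC4)[nH]n3)c3ccccc3n2)c(F)c1`) gives 1700 nM as the only number so far. Compound 2 (`Cc1cc(Nc2nc(NCc3ccc(F)cc3F)nc3cc(Cl)ccc23)n[nH]1`) shows > 100000 nM as a limit of the assay and not a number. Compound 3 (`Fc1ccc(CNc2nc(Nc3cc(C4CC4)[nH]n3)c3ccc(C(F)(F)F)cc3n2)c(F)c1`) carries trifluoromethyl in place of hydrogen on an aromatic carbon of the core of compound 1 (trifluoromethyl in place of hydrogen on an aromatic carbon). For the measured compounds named here, no measured step covers this change, so what is expected is a modest 2.1-fold higher number from compound 1 to compound 3 (0.31 log units; beyond the scatter) in this assay with weaker inhibition as the likelier direction. Compound 3 is estimated at 3500 nM with 600 nM to 20000 nM as its expected range.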

Compound 3, half-maximal inhibitory concentration: 9100 nM
Compound 3: middle estimate off by 2.6-fold (0.41 log units), on the low side; measured number inside the range.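

Trifluoromethyl in place of hydrogen on this aromatic carbon of the core gives a 5.4-fold higher number from compound 1 to compound 3 (0.73 log units; beyond the scatter) in this assay, the only measured step at this position, and it runs towards weaker inhibition. Compounds 1 and 2 differ in more than one place, so only compound 3 shows that this position responds to a change on its own. Nothing measured here gives a cause for this step. From the compounds shown here alone, whether an amine, a nitrile or a methoxy group on the same carbon would move the number the same way remains open.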